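This account rests on a few compounds, and the source may have more. Where it says the series, first, only, none or still open, it means among the compounds named here.

Measured so far in a functional assay on A549 cells (Homo sapiens) for antiproliferative activity, read by sulforhodamine B assay, with a stated time of 3 days; on this read-out higher numbers stand for weaker inhibition of growth and lower numbers for stronger inhibition of growth (values below):

- compound 1 `O=C(Nc1nccs1)c1cccc(Nc2ncc(F)c(Nc3ccc(F)cc3)n2)c1` gives > 10000 nM (a limit, not a number)
- compound 2 `O=C(Nc1cc(Cl)cc(Cl)c1)c1cccc(Nc2ncc(F)c(Nc3ccc(F)cc3)n2)c1` gives 17500 nM
- compound 3 `COc1cc(NC(=O)c2cccc(Nc3ncc(F)c(Nc4ccc(F)cc4)n3)c2)cc(OC)c1` gives 13900 nM

Compound 3 stands level with compound 2 (a 1.3-fold lower number from compound 2 to compound 3 (0.10 log units; within the scatter)). Compound 1 sits at a limit (the limit of > 10000 nM in this assay, at which 1 of the 3 values shown sits). Neither step out of compound 1 has a readable size (a step that the limit leaves unreadable from compound 1 to compound 2) (a step that the limit leaves unreadable from compound 1 to compound 3).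

The next compound, compound 4 `O=C(NCCO)c1cccc(Nc2ncc(F)c(Nc3ccc(F)cc3)n2)c1`, carries 2-hydroxyethyl in place of 3,5-dimethoxyphenyl on an amide-type nitrogen. The measured steps bear on this only loosely. For the measured compounds named here, the one readable step (a 1.3-fold lower number from compound 2 to compound 3 (0.10 log units; within the scatter)) exchanges 3,5-dichlorophenyl for 3,5-dimethoxyphenyl, and no measured compound has a group without a ring at this nitrogen. The expectation therefore rests on the level values of compound 2 (17500 nM) and compound 3 (13900 nM), and no step beyond the scatter is foreseen in this assay, in either direction. The expected step is small (a 1.2-fold higher number from compound 3 to compound 4 (0.06 log units; within the scatter)). For compound 4 the estimated value is 16000 nM, with an expected range from 7000 nM to 40000 nM. A report of only a limit is about as likely as a number.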

Compound 4, concentration for 50% growth inhibition: 11900 nM
Compound 4: middle estimate off by 1.3-fold (0.13 log units), on the high side, within the range that was stated.
By their numbers in this assay, from the lowest: compounds 4, 3 and 2 (each within the scatter of the next).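

In this assay, the amide-type nitrogen now carries a group with no ring, and 2-hydroxyethyl in place of 3,5-dimethoxyphenyl gives only a small step (a 1.2-fold lower number from compound 3 to compound 4 (0.07 log units; within the scatter)). The comparison with the other aryl amide, 2-hydroxyethyl in place of 3,5-dichlorophenyl, also stays small (a 1.5-fold lower number from compound 2 to compound 4 (0.17 log units; within the scatter)), so among compounds 2, 3 and 4 neither the six-membered aromatic ring nor the difference between 3 and 10 heavy atoms in this group separates the values. Compound 1 stands at a limit, not a number, and the steps out of it cannot be read: the limit of > 10000 nM in this assay, at which 1 of the 4 values shown sits.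

As far as these compounds go, whether any group at this nitrogen can bring the number clearly below those of compounds 2, 3 and 4 remains open, since the three groups with readable values, two substituted phenyl rings and one short hydroxyalkyl chain, all fall within the scatter of the next. An amine such as a 2-aminoethyl group, a carboxylic acid such as a carboxymethyl group, or a longer chain such as 4-hydroxybutyl would test whether this flat picture holds beyond the groups shown.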